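The source may report more compounds than this note shows. Statements on the series, on what has been measured and on what is new or still open speak of the compounds shown alone.

Compound 1 `Nc1nn(C(=O)Nc2ccc(Cc3ccccc3)cc2)c2ccccc12` and compound 2 `Nc1nn(C(=O)Nc2ccc(Cc3ccccc3)cc2)c2ccc(Cl)cc12` share one core and differ only in a chloro group on an aromatic carbon. In a functional assay on SK-MEL-2 cells (Homo sapiens) for antiproliferative activity, read by sulforhodamine B assay, with a stated time of 48 h (a lower number here means a stronger inhibitor of growth, a higher number a weaker inhibitor of growth), compound 1 reaches only the limit of the assay, > 100000 nM. In this assay compound 2 also stops at the assay limit, > 100000 nM. The step that the two limits leave unreadable from compound 1 to compound 2 is therefore unreadable, both values sitting at the limit of > 100000 nM in this assay, at which 2 of the 2 values shown sit. Compound 3 `Nc1ccc2c(c1)c(N)nn2C(=O)Nc1ccc(Cc2ccccc2)cc1` differs from compound 2 by amino in place of chloro on an aromatic carbon. For the measured compounds named here, no measured step bears on this change, so nothing beyond the scatter is expected in this assay. Compound 3 is estimated at 150000 nM, ranging from 50000 nM to 500000 nM. The expected step is a step that the limit leaves unreadable from compound 2 to compound 3.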

Compound 3, concentration for total growth inhibition: 48500 nM
The estimate for compound 3 lay 3.1-fold (0.49 log units) above the measured number, and the stated range ends above it.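

In this assay, the position first gives a readable response with amino: replacing chloro produces an at least 2.0-fold lower number from compound 2 to compound 3 (0.31 log units; beyond the scatter), and replacing hydrogen produces an at least 2.0-fold lower number from compound 1 to compound 3 (0.31 log units; beyond the scatter). Both steps are lower bounds, and the effect of chloro alone cannot be read, because compound 1 and compound 2 both stop at a limit: the limit of > 100000 nM in this assay, at which 2 of the 3 values shown sit. The amino group therefore brings a measurable number where neither hydrogen nor chloro did.

As far as these compounds go, it remains open how large the full steps are. From the compounds shown here alone, it also remains open whether a hydroxyl, a methylamino or an acetamido group at this position would act as amino does.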